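The source may hold more compounds than are shown below. What is called first, only, known or untested is meant among the compounds shown, and "the series" means these compounds.

Measured so far:
- compound 1, `Cc1c(CO/N=C/c2c(-c3ccccc3)nn(-c3ccccc3)c2Oc2ccc(Cl)cc2)cccc1-c1ccccc1`, gives -14.8%
- compound 2, `Cc1nn(-c2ccccc2)c(Oc2ccc(Cl)cc2)c1/C=N/OCc1ccc(C(=O)OC(C)(C)C)cc1`, gives -31.1%
- compound 3, `CC(C)c1nn(-c2ccccc2)c(Oc2ccc(Cl)cc2)c1/C=N/OCc1ccc(C(=O)OC(C)(C)C)cc1`, gives -14.7%

In a functional assay on HepG2 cells (Homo sapiens) for antiproliferative activity, tested at 1 uM (a higher number here means more inhibition at the concentration tested (going by the name of the read-out), a lower number less inhibition), compound 3 shows the highest of the three numbers, but compound 1 lies within the scatter of it, so the two cannot be told apart; only compound 2 sits clearly lower, with a number 16.4 percentage points higher from compound 2 to compound 3 (beyond the scatter) for isopropyl in place of methyl on an aromatic carbon.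

Compound 4, `CC(C)c1nn(-c2ccccc2)c(Oc2ccc(Cl)cc2)c1/C=N/OCc1ccc(C(F)(F)F)cc1`, differs from compound 3 by trifluoromethyl in place of tert-butoxycarbonyl on an aromatic carbon. Going by the values given here, none of the measured steps touches this part of the molecule; the one measured step concerns the isopropyl and methyl groups elsewhere and so gives no guidance here. With nothing to build on, a step within the scatter is the expectation, in either direction.

Compound 4 is therefore expected to give -12% in this assay, a step of a number 2.7 percentage points higher from compound 3 to compound 4 (within the scatter), with a range from -38% to 14%.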

Compound 4, a percentage reported as inhibition, at one concentration (the size of the read-out at that concentration, not a potency): -2.2%
The estimate for compound 4 lay 9.8 percentage points below the measured number; measured number inside the range.
By their numbers in this assay, from the lowest: compound 2; then compounds 1 and 3 (each within the scatter of the next); then compound 4.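

Changing the group on this six-membered aromatic ring, para to a large group, can move the result in this assay: trifluoromethyl in place of tert-butoxycarbonyl gives a number 12.5 percentage points higher from compound 3 to compound 4 (beyond the scatter), although compound 4 still gives a negative number, -2.2%. The group that leaves has more heavy atoms than the one that enters and also carries hydrogen-bond acceptors, so this single step cannot show which of these differences matters, or whether either does. No measured property is available to explain the step.

As far as these compounds go, it remains open whether an amine, a carboxylic acid or a longer chain at this place would bring the number above zero. From the compounds shown here alone, it is also open whether trifluoromethyl would give a similar step in a compound with methyl in place of isopropyl, such as compound 2.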